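Bromo in place of fluoro on compound 3

The source may report more compounds than this note shows. Statements on the series, on what has been measured and on what is new or still open speak of the compounds shown alone.

In an ADME assay on MT4 cells (Homo sapiens) for cytotoxicity, read by MTT assay, with a stated time of 5 days (a lower number here means that less compound is tolerated, a higher number that more compound is tolerated), compound 1 (`N#Cc1ccc(Nc2nccc(OCC(=O)Nc3ccc(F)cc3)n2)cc1`) reaches only a limit of > 344000 nM in this series. Compound 2 (`COc1ccc(NC(=O)COc2ccnc(Nc3ccc(C#N)cc3)n2)cc1`) likewise gives a limit of > 333000 nM and no number. Compound 3 (`Cc1cc(OCC(=O)Nc2ccc(F)cc2)nc(Nc2ccc(C#N)cc2)n1`) also stands at a limit, > 331000 nM like the other two values. Compound 4 (`Cc1cc(OCC(=O)Nc2ccc(Br)cc2)nc(Nc2ccc(C#N)cc2)n1`) has bromo in place of fluoro on an aromatic carbon is the whole change. The closest evidence is a step that the two limits leave unreadable from compound 1 to compound 2 at that same carbon, along with a step that the two limits leave unreadable from compound 1 to compound 3 elsewhere, so neither gives a size. The expected move is an at least 1.1-fold lower number from compound 3 to compound 4 (0.06 log units; that floor lies within the scatter) with no direction beyond the scatter. Compound 4 is estimated at 285000 nM within a range from 100000 nM to 400000 nM in this assay and may well again come out as a limit.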

Compound 4, half-maximal cytotoxic concentration: 930 nM
Estimate against measurement, compound 4: 310-fold (2.49 log units) above, and the stated range ends above it.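

In this assay, among the compounds shown here, the change from 4-fluorophenyl to 4-bromophenyl gives an at least 350-fold lower number from compound 3 to compound 4 (2.55 log units; beyond the scatter) and is the only step here that can be read, as the earlier steps cannot. Compound 2, with methoxy at that same carbon, remains only a limit (> 333000 nM), so this position first shows a measurable change with bromo. Nothing shown here accounts for the size of this step.

From the compounds shown here alone, whether chloro or iodo at this carbon would also lower the number remains open. So does whether bromo acts the same way on the core of compound 1, which lacks the methyl.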